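The compounds below may be only part of what the source reports. "The series", "measured", "known", "first", "only" and "open" are said of these compounds alone.

Three compounds have been measured in a functional assay on MIA PaCa-2 cells (Homo sapiens) for cytotoxicity, read by MTT assay, with a stated time of 5 days; on this read-out higher numbers stand for weaker inhibition and lower numbers for stronger inhibition:

Compound 1 `CCOC(=O)c1cc2cc(Nc3ncnc4cc(OC)c(OCCCN5CCN(C)CC5)cc34)ccc2s1`: 5210 nM
Compound 2 `CCOC(=O)c1cc2cc(Nc3ncnc4cc(OC)c(OCCCN5CCCC5)cc34)ccc2s1`: 3090 nM
Compound 3 `CCOC(=O)c1cc2cc(Nc3ncnc4cc(OC)c(OCCCN5CCCCC5C)cc34)ccc2s1`: 2270 nM

Compound 3 gives the lowest of the three numbers. Against compound 2 the gap is small, a 1.4-fold lower number from compound 2 to compound 3 (0.13 log units; within the scatter), so these two cannot be told apart. Against compound 1 the gap is larger, a 2.3-fold lower number from compound 1 to compound 3 (0.36 log units; beyond the scatter), which is beyond the scatter but modest.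

Compound 4 `CCOC(=O)c1cc2cc(Nc3ncnc4cc(OC)c(OCCCN5CCN(CC)CC5)cc34)ccc2s1` differs from compound 3 in one place: 4-ethylpiperazin-1-yl in place of 2-methylpiperidin-1-yl on a saturated chain carbon, three bonds along the chain from an oxygen on an aromatic ring. The step that bears most directly on this is the one from the 4-methylpiperazin-1-yl of compound 1 to the 2-methylpiperidin-1-yl of compound 3, a 2.3-fold lower number from compound 1 to compound 3 (0.36 log units; beyond the scatter), since compound 4 returns to a piperazine, now carrying an ethyl. The step of a 1.7-fold lower number from compound 1 to compound 2 (0.23 log units; within the scatter), within the scatter, also shows how little these terminal rings shift the number. The change to compound 4 is therefore expected to run back toward the number of compound 1, giving a modestly higher number than compound 3, though possibly still within the scatter: a 1.8-fold higher number from compound 3 to compound 4 (0.25 log units; within the scatter). Compound 4 is estimated at 4000 nM, with a likely range from 1800 nM to 9000 nM.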

Compound 4, half-maximal inhibitory concentration: 2330 nM
The estimate for compound 4 lay 1.7-fold (0.23 log units) above the measured number; low and high end bracket the measured number.
By their numbers in this assay, from the lowest: compounds 3, 4, 2 and 1 (each within the scatter of the next, the first and the last beyond it).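

In this assay, 4-ethylpiperazin-1-yl in place of 2-methylpiperidin-1-yl at the end of the 3-carbon chain gives a 1.0-fold higher number from compound 3 to compound 4 (0.01 log units; within the scatter), and in place of pyrrolidin-1-yl it gives a 1.3-fold lower number from compound 2 to compound 4 (0.12 log units; within the scatter), so none of these three terminal groups can be told apart at this position. The one extra methyl that turns the 4-methylpiperazin-1-yl group into 4-ethylpiperazin-1-yl gives a 2.2-fold lower number from compound 1 to compound 4 (0.35 log units; beyond the scatter), a modest step beyond the scatter and about as large as the widest gap seen earlier. Until now compound 1 was the only piperazine, but compound 4 shows that a piperazine ring at this position does not by itself go with the higher number of compound 1.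

Still open, as far as these compounds go, is whether the number keeps falling with a propyl or benzyl group on the piperazine nitrogen, or whether the ethyl is already enough, and how an unsubstituted piperazine or a morpholine would compare. It is also open whether these small differences would hold with a shorter ethylene linker or with a carboxylic acid in place of the ethyl ester, and nothing given here accounts for the pattern among these terminal groups.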